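Compound 4: A Methoxy Swap on an Inactive Compound

A few compounds are considered here, and "the series" means these few. Any claim that something is new, unique, unknown or untested is made for them only; others in the source may bear on it.

Measured so far in a functional assay on MCF7 cells (Homo sapiens) for antiproliferative activity, read by MTT assay, with a stated time of 72 h; on this read-out higher numbers stand for weaker inhibition and lower numbers for stronger inhibition:
Compound 1 `COc1ccc(/C=N/NC(=O)Nc2ccc(Oc3ccnc4[nH]ccc34)c(F)c2)cc1` gives 5750 nM
Compound 2 `O=C(N/N=C/c1ccc([N+](=O)[O-])cc1)Nc1ccc(Oc2ccnc3[nH]ccc23)cc1` gives 15600 nM
Compound 3 `O=C(N/N=C/c1cccc(Cl)c1Cl)Nc1ccc(Oc2ccnc3[nH]ccc23)cc1` gives "not active" (no number reported)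

Compound 3 has no place on the numerical scale. It is reported only as "not active" (no number reported), with no number, so the size of any step from it cannot be measured.

The step to follow is 4-methoxyphenyl in place of 2,3-dichlorophenyl on a carbon with a double bond to nitrogen. The resulting compound 4 `COc1ccc(/C=N/NC(=O)Nc2ccc(Oc3ccnc4[nH]ccc34)cc2)cc1` carries 4-methoxyphenyl in place of 2,3-dichlorophenyl on a carbon with a double bond to nitrogen.

In this assay, a move towards stronger inhibition is expected, from no number to a measurable one in the micromolar range of the other compounds. Compound 1 also carries 4-methoxyphenyl. Compound 1 gives 5750 nM. Compound 2 gives 15600 nM, a weaker number. With only these values to go on, the expectation is loose, and a report without a number remains possible.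

For compound 4 the estimated value is 8000 nM, with an expected range from 2500 nM to 25000 nM.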

Compound 4, half-maximal inhibitory concentration: "not active" (no number reported)
Compound 4: no number reported; there is nothing to compare the estimate with.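

In this assay, within the data shown here, compound 4, like compound 3, is reported only as not active, so no step between compound 3 and compound 4 can be read. The compounds shown leave open how far either one lies from a measurable value. Nothing available here bears on this result.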